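A few compounds are considered here, and "the series" means these few. Any claim that something is new, unique, unknown or untested is made for them only; others in the source may bear on it.

Series notes. In a functional assay on PC-3 cells (Homo sapiens) for antiproliferative activity, read by MTT assay (on this read-out lower numbers stand for stronger inhibition and higher numbers for weaker inhibition), compound 1 `Cn1c(=O)c(=O)n(C2CCCC2)c2nc(N/N=C/c3ccccc3)ncc21` gives 48200 nM and stands highest of the numbers in hand, with compound 3 nearest. Compound 3 `Cn1c(=O)c(=O)n(C2CCCC2)c2nc(N/N=C/c3ccc(F)cc3Cl)ncc21` gives 15200 nM; the change to it is a 3.2-fold lower number from compound 1 to compound 3 (0.50 log units; beyond the scatter). For compound 2 `Cn1c(=O)c(=O)n(C2CCCC2)c2nc(N/N=C/c3ccc(O)cc3)ncc21` the read-out is > 100000 nM, a limit of this assay rather than a number. From that limit follow an at least 2.0-fold higher number from compound 1 to compound 2 (0.31 log units; beyond the scatter) and an at least 6.5-fold lower number from compound 2 to compound 3 (0.81 log units; beyond the scatter).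

Compound 4 `Cn1c(=O)c(=O)n(C2CCCC2)c2nc(N/N=C/c3ccc(F)cc3Br)ncc21` differs from compound 1 by 2-bromo-4-fluorophenyl in place of phenyl on a carbon with a double bond to nitrogen. Among the compounds with values here, the one measured step that bears on this change is the one carrying a 2-chloro-4-fluorophenyl onto compound 3, a modest fall beyond the scatter; the incoming 2-bromo-4-fluorophenyl differs from it only in bromine in place of chlorine. A step of similar size and the same direction is therefore expected for compound 4, namely a 3.2-fold lower number from compound 1 to compound 4 (0.51 log units; beyond the scatter). On that basis compound 4 is estimated at 15000 nM, with a range of 6000 nM to 40000 nM.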

Compound 4, half-maximal inhibitory concentration: 9250 nM
Compound 4: the middle estimate sits 1.6-fold (0.21 log units) above what was measured; the range from low to high includes it.
By their numbers in this assay, from the lowest: compounds 4 and 3 (each within the scatter of the next); then compound 1. At a limit, above all of these: compound 2.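

In this assay a second halogenated phenyl on the carbon with a double bond to nitrogen also lowers the number, a 5.2-fold lower number from compound 1 to compound 4 (0.72 log units; beyond the scatter), so the fall seen with compound 3 is not confined to the 2-chloro-4-fluorophenyl group. Bromo in place of chloro gives no separable change, a 1.6-fold lower number from compound 3 to compound 4 (0.22 log units; within the scatter), and the two compounds cannot be ordered. The step from the 4-hydroxyphenyl group, an at least 10-fold lower number from compound 2 to compound 4 (1.03 log units; beyond the scatter), rests on a limit of the assay and not on a number, and so gives only a bound: the limit of > 100000 nM in this assay, at which 1 of the 4 values shown sits.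

Compounds 3 and 4 both carry fluoro, so the compounds shown do not separate its contribution from that of chloro or bromo. Going by these compounds, whether a methoxy, a nitrile or an amine in place of bromo would keep the number this low remains open.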